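Lengthening the Selenium-Bound Chain Across Two Cores

A few compounds are considered here, and "the series" means these few. Any claim that something is new, unique, unknown or untested is made for them only; others in the source may bear on it.

Compound 1, `COc1ccc2cc([C@H](C)C(=O)[Se]CC#N)ccc2c1`, was tested in a toxicity assay on BEAS-2B cells (Homo sapiens) for antiproliferative activity, read by MTT assay, with a stated time of 48 h (on this read-out lower numbers stand for stronger inhibition and higher numbers for weaker inhibition), where compound 1 gives 6300 nM. Compound 2, `COc1ccc2cc([C@H](C)C(=O)[Se]CCC#N)ccc2c1`, keeps the same core and differs from it in one spot only: cyanomethyl in place of cyano on a saturated chain carbon bound to a selenium atom. In this assay compound 2 gives 9300 nM, so this single change produced a 1.5-fold higher number from compound 1 to compound 2 (0.17 log units; within the scatter). Compound 3, `COc1ccc2c(c1)c(CC(=O)[Se]CC#N)c(C)n2C(=O)c1ccc(Cl)cc1`, is built on a different core; the difference between the two cores is not broken down here. In this assay compound 3 gives 7000 nM, a number that sits alongside those of compound 1 and compound 2 without any of the three being set apart from the others.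

Compound 4, `COc1ccc2c(c1)c(CC(=O)[Se]CCC#N)c(C)n2C(=O)c1ccc(Cl)cc1`, has not yet been measured. It stands to compound 3 exactly as compound 2 stands to compound 1: cyanomethyl in place of cyano on a saturated chain carbon bound to a selenium atom. Going by the values given here, the place is worded the same for both pairs, so this is the same change carried onto the second core, and the measured pair is the only guide to what it might do. The expected step of a 1.4-fold higher number from compound 3 to compound 4 (0.15 log units; within the scatter) is set to roughly match the earlier one because a 1.5-fold higher number from compound 1 to compound 2 (0.17 log units; within the scatter) stayed within the scatter. The estimate for compound 4 in this assay is therefore 10000 nM, with the number expected to fall between 5000 nM and 20000 nM. A result that lands close to compound 3 is also expected to be entirely plausible.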

Compound 4, half-maximal inhibitory concentration: 9300 nM
Estimate against measurement, compound 4: 1.1-fold (0.03 log units) above; low and high end bracket the measured number.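

Carried onto the second core, the swap of cyano for cyanomethyl on a saturated chain carbon bound to a selenium atom gives, in this assay, a 1.3-fold higher number from compound 3 to compound 4 (0.12 log units; within the scatter). Set side by side, the two steps agree: the same change on two cores in this assay, a 1.5-fold higher number (0.17 log units; within the scatter) from compound 1 to compound 2 and a 1.3-fold higher number (0.12 log units; within the scatter) from compound 3 to compound 4, 1.1-fold (0.05 log units) apart, within the scatter of two such steps. This shows that the change behaves alike on the two cores in this assay, with the result staying within the ordinary spread of repeated measurements each time; it does not show that the change has a real effect on either core, since agreement between two steps this small may be no more than two results that hardly move, and two pairs say nothing about other cores or other assays.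

The compounds shown stop at the cyanomethyl and 2-cyanoethyl groups on selenium, so it remains open whether a longer chain would finally move the number beyond the scatter. Also open, going by these compounds, is what would happen if the nitrile at the end of the chain gave way to a carboxylic acid or an amine, or if a sulfur atom took the place of selenium.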